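Carrying the Series from Compound 3 to Compound 4

A few compounds are considered here, and "the series" means these few. Any claim that something is new, unique, unknown or untested is made for them only; others in the source may bear on it.

Three compounds have so far been measured in a functional assay on FL5.12 cells (Mus musculus), read by flow cytometry, with a stated time of 3 h, tested at 10 uM; on this read-out lower numbers stand for a weaker effect and higher numbers for a stronger effect at the one concentration tested:
Compound 1, `CCCCCCCCc1ccc(CC[C@@H]2CCCN2)cc1`, gives 63%.
Compound 2, `CCCCCCCCc1ccc(C(C[C@@H]2CCCN2)OC)cc1`, gives 58%.
Compound 3, `CCCCCCCCc1ccc(C(=O)C[C@@H]2C[C@@H](O)CN2)cc1`, gives 46%.

On these numbers compound 3 stands lowest of the three in this assay; the nearest to it is compound 2 and the furthest is compound 1, and both of those gaps lie beyond the usual scatter. Compound 4, `CCCCCCCCc1ccc(C(=O)CC[C@H]2C[C@H](CO)CN2)cc1`, has not yet been measured. It differs from compound 3 by a group of 8 heavy atoms (6 carbon, 1 nitrogen, 1 oxygen; one five-membered non-aromatic ring with 1 hetero atom) in place of a group of 6 heavy atoms (4 carbon, 1 nitrogen, 1 oxygen; one five-membered non-aromatic ring with 1 hetero atom), on a saturated chain carbon bound to a carbonyl carbon. Among the measured compounds shown here, the one step measured between compounds that differ in a single place is a number 5 percentage points lower from compound 1 to compound 2 (within the scatter), and that step concerns a methoxy in place of hydrogen, not the group that leaves or the group that enters here. For the measured compounds named here, no measured pair shows what the present change does. With nothing that bears on it directly, the expectation can rest only on compound 3 itself. Compound 4 is therefore expected to sit close to compound 3, with an estimated step of no change at the digits printed from compound 3 to compound 4 (within the scatter), not beyond the scatter. The estimate for compound 4 in this assay is 46%, within a range from 30% to 62%.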

Compound 4, a percentage reported as activity, at one concentration (the size of the read-out at that concentration, not a potency): 46%
The estimate for compound 4 equals the measured number at the digits printed; the range from low to high includes it.
By their numbers in this assay, from the lowest: compounds 3 and 4 (each within the scatter of the next); then compounds 2 and 1 (each within the scatter of the next).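

In this assay, among the compounds shown here, the exchange gives no change at the digits printed from compound 3 to compound 4 (within the scatter), the first reading at this place, on a saturated chain carbon bound to a carbonyl carbon. The earlier step concerned only a methoxy in place of hydrogen, whereas this one shows that a group of 8 heavy atoms can take the place of 4-hydroxypyrrolidin-2-yl, with its group of 6 heavy atoms, and leave the read-out where it was, while the five-membered non-aromatic ring and the counts of hydrogen-bond donors, hydrogen-bond acceptors and defined stereocentres stay the same. No measurement is at hand that would explain this outcome.

The step exchanges the whole group at once, so the two compounds cannot separate the part played by the added heavy atoms from that of the defined stereocentres, and a single pair cannot show whether the same exchange would leave the read-out unchanged on another core. Going by these compounds, it also remains open whether a group that keeps the five-membered ring but carries an amine or a carboxylic acid instead of the hydroxyl would read the same at this place.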